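A few compounds are considered here, and "the series" means these few. Any claim that something is new, unique, unknown or untested is made for them only; others in the source may bear on it.

Measured compounds:
Compound 1 `COc1cc(Cl)cc(-c2nn(-c3cccc(NC(=O)Nc4ccc(Cl)c(C(F)(F)F)c4)c3)cc2-c2ccncc2)c1` — 3.99%
Compound 2 `COc1cc(Cl)cc(-c2nn(-c3cccc(NC(=O)Nc4cccc(C(F)(F)F)c4)c3)cc2-c2ccncc2)c1` — 9.99%

Both numbers come from a functional assay on M14 cells (Homo sapiens) for inhibition, read by sulforhodamine B assay, with a stated time of 48 h, tested at 10 uM; on this read-out lower numbers stand for a stronger effect and higher numbers for a weaker effect at the one concentration tested. Within the data shown here, compound 2 stands highest of the two numbers, the only step leading to it being a number 6 percentage points higher from compound 1 to compound 2 (within the scatter). Compound 3 `COc1cc(Cl)cc(-c2nn(-c3cccc(NC(=O)c4cccc(C(F)(F)F)c4)c3)cc2-c2ccncc2)c1` has not yet been measured; it differs from compound 2 by 3-(trifluoromethyl)phenyl in place of (3-(trifluoromethyl)phenyl)amino on a carbonyl carbon. Among the measured compounds shown here, the single measured step, a number 6 percentage points higher from compound 1 to compound 2 (within the scatter), concerns hydrogen in place of chloro on an aromatic carbon and does not bear on this change; no measured step does. With nothing to point a direction, compound 3 is expected to sit near compound 2, an estimated step of a number 5 percentage points higher from compound 2 to compound 3 (within the scatter), within a wide range. In this assay compound 3 is estimated at 15%, from 3% to 45%.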

Compound 3, a percentage reported as activity, at one concentration (the size of the read-out at that concentration, not a potency): 56.3%
Compound 3: middle estimate off by 41.3 percentage points, on the low side; measured number outside the range, above it.
By their numbers in this assay, from the lowest: compounds 1 and 2 (each within the scatter of the next); then compound 3.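

In this assay, the group on the carbonyl carbon proves decisive: 3-(trifluoromethyl)phenyl in place of (3-(trifluoromethyl)phenyl)amino gives a number 46.3 percentage points higher from compound 2 to compound 3 (beyond the scatter), a large loss of effect that the chloro change never produced. Set against the chlorinated urea, the loss is of similar size, with a number 52.3 percentage points higher from compound 1 to compound 3 (beyond the scatter). No evidence at hand accounts for this loss. The compounds shown leave open whether a methylene group or an ether oxygen joining the carbonyl carbon to the aromatic ring would restore the effect seen with compound 1 and compound 2.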